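The source may report more compounds than this note shows. Statements on the series, on what has been measured and on what is new or still open speak of the compounds shown alone.

Measured in a functional assay on HOP-62 cells (Homo sapiens) for inhibition, read by sulforhodamine B assay, with a stated time of 48 h; on this read-out higher numbers stand for weaker inhibition of growth and lower numbers for stronger inhibition of growth:
compound 1 `Nc1cc(N)c2nc(-c3ccccc3)c(NCc3ccc(Cl)c(Cl)c3)nc2c1` gives 15800 nM
compound 2 `COc1ccc(CNc2nc3cc(N)cc(N)c3nc2-c2ccccc2)cc1OC` gives 18200 nM
compound 3 `Nc1cc(N)c2nc(-c3ccccc3)c(NCc3ccc(F)cc3)nc2c1` gives 38900 nM

Compound 3 carries the highest number of the three: the steps of a 2.5-fold higher number from compound 1 to compound 3 (0.39 log units; beyond the scatter) and a 2.1-fold higher number from compound 2 to compound 3 (0.33 log units; beyond the scatter) both lie beyond the scatter, whereas a 1.2-fold higher number from compound 1 to compound 2 (0.06 log units; within the scatter) does not. Compound 4 `COc1ccc(CNc2nc3cc(N)cc(N)c3nc2-c2ccccc2)cc1` differs from compound 3 by methoxy in place of fluoro on an aromatic carbon. Within the data shown here, two measured steps bear on this change: moving from the 3,4-dichlorophenyl or the 3,4-dimethoxyphenyl group to the 4-fluorophenyl group raised the number modestly in each case, so putting a methoxy back onto the ring in place of the fluoro is expected to lower it modestly, with the caution that a single methoxy is not the dimethoxy pattern of compound 2. For compound 4 the expected step is a 1.6-fold lower number from compound 3 to compound 4 (0.19 log units; within the scatter). The estimate for compound 4 is 25000 nM, between 12000 nM and 50000 nM.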

Compound 4, concentration for 50% growth inhibition: 17400 nM
Estimate against measurement, compound 4: 1.4-fold (0.16 log units) above, and the stated range covers the measured number.
By their numbers in this assay, from the lowest: compounds 1, 4 and 2 (each within the scatter of the next); then compound 3.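

In this assay, methoxy in place of fluoro, para to a large group, gives a real gain in growth inhibition (a 2.2-fold lower number from compound 3 to compound 4 (0.35 log units; beyond the scatter)). Taking one methoxy away from the dimethoxy pattern leaves no measurable change (a 1.0-fold lower number from compound 2 to compound 4 (0.02 log units; within the scatter)), and the 4-methoxyphenyl group also matches the 3,4-dichlorophenyl group (a 1.1-fold higher number from compound 1 to compound 4 (0.04 log units; within the scatter)), so among these four compounds only compound 3, with its fluoro, stands apart. Nothing measured here explains the fluoro result.

Still open, on these data alone, is whether a hydroxyl or an amine in place of the methoxy would move the number away from that of compound 4. The same question applies to a longer chain carrying the 4-methoxyphenyl group.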